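Compound 2 to compound 4: change on the amide nitrogen

The compounds below may be only part of what the source reports. "The series", "measured", "known", "first", "only" and "open" are said of these compounds alone.

Among the measured compounds shown here, in a functional assay on HeLa cells (Homo sapiens) for inhibition, read by MTT assay, with a stated time of 48 h (on this read-out higher numbers stand for weaker inhibition and lower numbers for stronger inhibition), compound 2 `COc1ccc2c(=O)c(/C=C/C(=O)Nc3cc(C)ccc3C)coc2c1` gives 58400 nM, the only true number so far. Compound 1 `O=C(/C=C/c1coc2cc(O)ccc2c1=O)NCc1ccccc1` reads > 100000 nM, which is a limit of the assay and not a number. Compound 3 `O=C(/C=C/c1coc2cc(O)ccc2c1=O)NCc1ccc(F)cc1` reads > 100000 nM, which is likewise only a limit. Compound 2 is therefore the single measured anchor, with no second number to rank it against.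

The change to compound 4 `COc1ccc2c(=O)c(/C=C/C(=O)NCc3ccc(C)cc3)coc2c1` is 4-methylbenzyl in place of 2,5-dimethylphenyl on an amide-type nitrogen. In words, 4-methylbenzyl stands in place of 2,5-dimethylphenyl on an amide-type nitrogen, and the two compounds have the same atoms, joined differently.

For the measured compounds named here, the only measured step is a step that the two limits leave unreadable from compound 1 to compound 3, fluoro in place of hydrogen on an aromatic carbon. It sets no size because of the limit of > 100000 nM in this assay, at which 2 of the 3 values shown sit. Going by the values given here, no measured step covers the exchange made at the amide nitrogen, so the data offer no size or direction to carry over. No shift beyond the usual scatter is therefore expected in this assay, although a reading that reaches only the limit remains a real possibility.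

The expected change is a 1.2-fold higher number from compound 2 to compound 4 (0.08 log units; within the scatter). Compound 4 is estimated at 70000 nM, with an expected range of 30000 nM to 160000 nM.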

Compound 4, half-maximal inhibitory concentration: > 100000 nM
Compound 4 ended at the assay's limit; the forecaster's own chance of this, stated with the estimate: 45%; middle value at least 1.4-fold (0.15 log units) away from the limit.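

In this assay, among the compounds shown here, the amide nitrogen is the first position to give a readable step: 4-methylbenzyl in place of 2,5-dimethylphenyl gives an at least 1.7-fold higher number from compound 2 to compound 4 (0.23 log units; that floor lies within the scatter). This figure is only a floor and lies within the usual scatter, so the step alone does not separate compound 4 from compound 2, and it sets no upper size for the exchange. Compound 2 remains the only compound with a true number, and what can be read at this nitrogen is capped because of the ceiling of the read-out: the limit of > 100000 nM in this assay, at which 3 of the 4 values shown sit.

From the compounds shown here alone, the true size of the step stays open, as does whether any group on this nitrogen can give a number clearly apart from that of compound 2. The compounds shown also leave open how a group of a different kind, such as a 2-aminoethyl chain or a benzyl group carrying a carboxylic acid, would read on the same amide nitrogen against 2,5-dimethylphenyl.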